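The source may hold more compounds than are shown below. What is called first, only, known or untested is meant among the compounds shown, and "the series" means these compounds.

Of the compounds shown here, two have so far been measured in an assay on CHO cells for displacement of a labelled ligand from prostaglandin D2 receptor 2 (Homo sapiens), read by scintillation counting; a higher number here means a weaker inhibitor, a lower number a stronger inhibitor. Compound 1 `CN(C)S(=O)(=O)c1ccc(F)c(C#Cc2cc(Cl)ccc2OCC(=O)O)c1` gives 3.1 nM in this assay, and compound 2 `CC(C)c1ccc(S(C)(=O)=O)cc1C#Cc1cc(Cl)ccc1OCC(=O)O` gives 4.6 nM in this assay. Compound 2 holds the highest of the two numbers, yet its gap to compound 1 lies within the scatter. Compound 3 `CS(=O)(=O)c1ccc(F)c(C#Cc2cc(Cl)ccc2OCC(=O)O)c1` has not yet been measured; it differs from compound 2 by fluoro in place of isopropyl on an aromatic carbon. Within the data shown here, no step between measured compounds is available, so in this assay the expected step is a 1.2-fold lower number from compound 2 to compound 3 (0.06 log units; within the scatter), none beyond the scatter. Compound 3 is estimated at 4 nM, with a range from 1.5 nM to 10 nM.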

Compound 3, inhibition constant: 3.3 nM
For compound 3 the middle estimate is 1.2-fold (0.08 log units) above the measured one; measured number inside the range.
By their numbers in this assay, from the lowest: compounds 1, 3 and 2 (each within the scatter of the next).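

In this assay, fluoro in place of isopropyl on the aromatic carbon para to a methylsulfonyl group gives a 1.4-fold lower number from compound 2 to compound 3 (0.14 log units; within the scatter) and so shows that this position accepts either group with no change beyond the scatter. Methyl in place of dimethylamino on the sulfonyl sulfur gives a 1.1-fold higher number from compound 1 to compound 3 (0.03 log units; within the scatter) and likewise leaves the number within the scatter. Nothing available explains either result. As far as these compounds go, whether an amine or a methoxy group at the fluoro position would hold the number remains open, as does the effect of a longer chain on the sulfonyl sulfur.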